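Benzyl variation on the shared core: toward compound 4

The compounds below may be only part of what the source reports. "The series", "measured", "known", "first", "only" and "open" are said of these compounds alone.

Measured so far:
compound 1, `Nc1cc(N)c2nc(-c3ccccc3)c(NCc3ccc(Cl)c(Cl)c3)nc2c1`, 24000 nM
compound 2, `COc1cc(CNc2nc3cc(N)cc(N)c3nc2-c2ccccc2)cc(OC)c1OC`, 21400 nM
compound 3, `CCOC(=O)[C@H](CCC(=O)O)NC(=O)c1ccc(CNc2nc3cc(N)cc(N)c3nc2-c2ccccc2)cc1`, a limit only: < 100000 nM
compound 4, `Nc1cc(N)c2nc(-c3ccccc3)c(NCc3ccc(F)cc3)nc2c1`, not yet measured

The read-out is a functional assay on OVCAR-5 cells (Homo sapiens) for inhibition, read by sulforhodamine B assay, with a stated time of 48 h; a higher number here means a weaker inhibitor of growth, a lower number a stronger inhibitor of growth. Of the two numbers in hand, compound 1 stands with the higher one, yet compound 2 sits within the usual scatter of it, so the two cannot be separated. Compound 3 is known only as a limit, (the limit of < 100000 nM in this assay, at which 1 of the 3 values shown sits), and carries no number to compare.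

Going by the values given here, no pair of measured compounds differs in a single place, so no measured step on this core exists to lean on. The change from compound 1 to compound 4 is 4-fluorophenyl in place of 3,4-dichlorophenyl on a saturated chain carbon bound to a nitrogen on an aromatic ring.

With nothing in the series to set the size of this step, the expectation rests on compound 1 alone, which gives 24000 nM. The expected step is a modest one toward a higher number, or none beyond the scatter, written as a 1.5-fold higher number from compound 1 to compound 4 (0.16 log units; within the scatter). Compound 4 is therefore estimated at 35000 nM, with a range from 12000 nM to 100000 nM, and some chance that only a limit is reported.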

Compound 4, concentration for 50% growth inhibition: 2630 nM
The estimate for compound 4 lay 13-fold (1.12 log units) above the measured number; the measured number lies below the stated range.
By their numbers in this assay, from the lowest: compound 4; then compounds 2 and 1 (each within the scatter of the next).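

Going by these compounds alone, the exchange of 3,4-dichlorophenyl for 4-fluorophenyl on a saturated chain carbon bound to a nitrogen on an aromatic ring gives, in this assay, a 9.1-fold lower number from compound 1 to compound 4 (0.96 log units; beyond the scatter), the only measured step on the shared core that changes a single place. The earlier compounds shown here, among which no pair differed in one place, could not show that this position responds to the halogens on the phenyl ring, and here the response lies beyond the scatter; the step, however, removes one chlorine and replaces the other with fluorine together, so it does not separate these two changes. Nothing at hand gives a measured property that bears on this step.

A 4-chlorophenyl and a 3-fluorophenyl at this position would be needed to assign the difference to one halogen or the other, and a longer chain between the phenyl ring and the nitrogen would test whether the single saturated carbon matters. Whether the phenyl ring on the core tolerates any change also stays open, as every compound shown carries it unchanged.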